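Swapping the Benzothiazole Group for a Thiophene

The compounds below may be only part of what the source reports. "The series", "measured", "known", "first", "only" and "open" are said of these compounds alone.

Measured compounds:
Compound 1 `CC(C)(C)Sc1c(CC(C)(C)C(=O)O)n(Cc2ccc(Cl)cc2)c2ccc(OCc3nc4ccccc4s3)cc12` gives 3 nM
Compound 2 `COc1ccc2nc(COc3ccc4c(c3)c(SC(C)(C)C)c(CC(C)(C)C(=O)O)n4Cc3ccc(Cl)cc3)sc2c1` gives 8 nM
Compound 3 `CC(C)(C)Sc1c(CC(C)(C)C(=O)O)n(Cc2ccc(Cl)cc2)c2ccc(OCc3cnccn3)cc12` gives 4 nM

The three compounds share one core and differ only in the ring attached through a methoxy linker to the aromatic ring. They were tested in a functional assay for inhibition, with Homo sapiens as the target (on this read-out lower numbers stand for stronger inhibition and higher numbers for weaker inhibition), where compound 1 gives 3 nM, the lowest number of the three. The gap to compound 2 is a 2.7-fold higher number from compound 1 to compound 2 (0.43 log units; beyond the scatter), while the gap to compound 3 is a 1.3-fold higher number from compound 1 to compound 3 (0.12 log units; within the scatter), so compound 1 and compound 3 cannot be told apart on these numbers.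

Compound 4 `CC(C)(C)Sc1c(CC(C)(C)C(=O)O)n(Cc2ccc(Cl)cc2)c2ccc(OCc3cccs3)cc12` is the next member. It differs from compound 1 by thiophen-2-yl in place of 1,3-benzothiazol-2-yl on a saturated chain carbon bound to an oxygen on an aromatic ring.

Among the compounds with values here, two measured steps bear on this change. The step of a 1.3-fold higher number from compound 1 to compound 3 (0.12 log units; within the scatter) shows that replacing the benzothiazolyl group with a smaller, single-ring heteroaryl leaves the number essentially unchanged. The step of a 2.0-fold lower number from compound 2 to compound 3 (0.30 log units; within the scatter) likewise stays within the scatter. On that basis the step to the thiophene is expected to be small, a 1.3-fold higher number from compound 1 to compound 4 (0.12 log units; within the scatter), with no direction that the data can settle. The number for compound 4 is therefore estimated at 4 nM, with a likely range from 2 nM to 10 nM.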

Compound 4, half-maximal inhibitory concentration: 4 nM
Beside the measured number, compound 4's estimate shows no gap at the digits printed; the measured number falls inside the stated range.
By their numbers in this assay, from the lowest: compounds 1, 3, 4 and 2 (each within the scatter of the next, the first and the last beyond it).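

In this assay, the single five-membered ring of thiophen-2-yl, with 5 heavy atoms and no nitrogen, can stand on a saturated chain carbon bound to an oxygen on an aromatic ring in place of 1,3-benzothiazol-2-yl, with 9 heavy atoms, at a 1.3-fold higher number from compound 1 to compound 4 (0.12 log units; within the scatter), and it also matches pyrazin-2-yl, at no change at the digits printed from compound 3 to compound 4 (within the scatter). This adds a ring without nitrogen to the earlier result for pyrazin-2-yl, so among these compounds, neither a ring nitrogen nor the larger 1,3-benzothiazol-2-yl group is needed to keep the number in this range. Compound 2 stays close to the thiophene as well, at a 2.0-fold lower number from compound 2 to compound 4 (0.30 log units; within the scatter), although it is separated from compound 1 by a step beyond the scatter, and no available evidence explains why such different rings give such similar numbers.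

Every group shown at this place is an aromatic ring, so it remains open whether a saturated ring such as piperidine, an amine or a carboxylic acid would be accepted there. As far as these compounds go, it is also open whether thiophen-2-yl would give a similar number if another part of the shared core changed, such as the 4-chlorobenzyl group.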